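The source may report more compounds than this note shows. Statements on the series, on what has been measured and on what is new or still open speak of the compounds shown alone.

Compounds measured so far:
Compound 1, `C[C@@H]1COC[C@@H](C)N1S(=O)(=O)c1ccc(NC(=O)NCc2cccnc2)cc1`, 52 nM.
Compound 2, `O=C(NCc1cccnc1)Nc1ccc(S(=O)(=O)N2C3CCC2COC3)cc1`, 10 nM.

Among the compounds with values here, in an assay on isolated protein for inhibition of Nicotinamide phosphoribosyltransferase (Homo sapiens), read by spectrophotometry, with stated times of 15 min and 30 min (on this read-out higher numbers stand for weaker inhibition and lower numbers for stronger inhibition), compound 2 holds the lowest of the two numbers, and its only neighbour is compound 1, a step of a 5.2-fold lower number from compound 1 to compound 2 (0.72 log units; beyond the scatter) away. Compound 3, `O=C(NCc1cccnc1)Nc1ccc(S(=O)(=O)N2CC3(COC3)C2)cc1`, carries the change (a group of 7 heavy atoms (5 carbon, 1 nitrogen, 1 oxygen; 2 four-membered non-aromatic rings with 1 hetero atom each) in place of a group of 8 heavy atoms (6 carbon, 1 nitrogen, 1 oxygen; one five-membered non-aromatic ring with 1 hetero atom, one six-membered non-aromatic ring with 2 hetero atoms), on a sulfonyl sulfur). Within the data shown here, only one measured step bears on this position: a 5.2-fold lower number from compound 1 to compound 2 (0.72 log units; beyond the scatter), where a different group on the same sulfonyl sulfur moved the number by a modest amount, beyond the scatter. That step shows the position tolerates exchange of the ring group, but it says nothing directly about the two four-membered rings now entering. The number for compound 3 is therefore expected to stay near compound 2, with a step of a 3.0-fold higher number from compound 2 to compound 3 (0.48 log units; beyond the scatter) in this assay judged more likely than none. Compound 3 is estimated at 30 nM, within a range from 8 nM to 120 nM.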

Compound 3, half-maximal inhibitory concentration: 103 nM
For compound 3 the middle estimate is 3.4-fold (0.54 log units) below the measured one, and the stated range covers the measured number.
By their numbers in this assay, from the lowest: compound 2; then compounds 1 and 3 (each within the scatter of the next).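

In this assay, the group on the sulfonyl sulfur now produces a large step in the opposite direction from the earlier one: a 10-fold higher number from compound 2 to compound 3 (1.01 log units; beyond the scatter). The low number of compound 2 is therefore not kept when the 2 four-membered non-aromatic rings enter, even though both groups have no hydrogen-bond donors, 1 hydrogen-bond acceptor and no net charge, while a 2.0-fold higher number from compound 1 to compound 3 (0.30 log units; within the scatter) leaves compound 3 within the scatter of compound 1. No measurement available here accounts for this difference.

The compounds shown leave open whether a simpler group on the sulfonyl sulfur, such as unsubstituted morpholine or piperidine, would give a number near that of compound 2 or that of compound 3. They also do not show how a ring amine in place of the ring oxygen would affect the number.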